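The source may report more compounds than this note shows. Statements on the series, on what has been measured and on what is new or still open speak of the compounds shown alone.

Measured compounds:
compound 1, `CCCc1ccc(S(=O)(=O)NC(=O)OCCC(F)(F)C(F)(F)F)c(-c2ccc(Cn3c(C(C)(C)C)nc4ccccc43)cc2)c1`, 6 nM
compound 2, `CCCc1ccc(S(=O)(=O)NC(=O)OCCCC(F)(F)F)c(-c2ccc(Cn3c(C(C)(C)C)nc4ccccc43)cc2)c1`, 4.5 nM
compound 3, `CCCCOC(=O)NS(=O)(=O)c1ccc(CCC)cc1-c1ccc(Cn2c(-c3ccccc3)nc3ccccc32)cc1`, 590 nM

In an assay on membranes from HEK293 cells for displacement of a labelled ligand from Type-2 angiotensin II receptor (Homo sapiens), read by radioligand binding (on this read-out lower numbers stand for stronger inhibition and higher numbers for weaker inhibition), compound 3 gives the highest number of the three, which is also the weakest inhibition among them. Compound 4, `CCCCOC(=O)NS(=O)(=O)c1ccc(CCC)cc1-c1ccc(Cn2c(C)nc3ccccc32)cc1`, is not yet measured. It differs from compound 3 in one place: methyl in place of phenyl on an aromatic carbon, on an aromatic carbon of a five-membered aromatic ring that is part of a fused system of two rings.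

Within the data shown here, the only measured step, from compound 1 to compound 2, is a 1.3-fold lower number from compound 1 to compound 2 (0.12 log units; within the scatter); it concerns a fluorinated chain carbon far from the ring in question and does not bear on the change at hand. Compounds 1 and 2 carry a different group at that ring carbon, but they also differ from compound 3 in the chain on the other side, so their values cannot isolate the effect of the ring substituent. Among the measured compounds shown here, no measured step covers the exchange of phenyl for methyl. The expected step from compound 3 to compound 4 in this assay is therefore a 1.5-fold lower number from compound 3 to compound 4 (0.17 log units; within the scatter), essentially no change beyond the scatter, with a wide range. Compound 4 is expected to give about 400 nM, within 80 nM to 2000 nM.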

Compound 4, inhibition constant: 9.4 nM
Beside the measured number, compound 4's estimate is 43-fold (1.63 log units) above it; measured number outside the range, below it.
By their numbers in this assay, from the lowest: compounds 2, 1 and 4 (each within the scatter of the next, the first and the last beyond it); then compound 3.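

Exchanging phenyl for methyl on this aromatic carbon, between two ring nitrogen atoms, gives a 63-fold lower number from compound 3 to compound 4 (1.80 log units; beyond the scatter) in this assay, a large step well beyond the scatter. Among these compounds, the earlier compounds could not show this: their only measured step lay in a fluorinated chain, and it stayed within the scatter. This ring carbon is therefore a place where the choice of group matters strongly, and with the rest of the molecule unchanged, the single carbon of methyl goes with far stronger inhibition than the six carbons of phenyl.

Still open, as far as these compounds go, is how an ethyl group, a longer chain or an amine on this same carbon would compare with methyl and phenyl. Nothing measured on these compounds gives a reason for the size of this step.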